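A few compounds are considered here, and "the series" means these few. Any claim that something is new, unique, unknown or untested is made for them only; others in the source may bear on it.

Three compounds have numbers in an assay on HEK293 cells for agonist activity at Bile acid receptor (Homo sapiens), read by a luciferase reporter; on this read-out higher numbers stand for an effect only at larger amounts of compound and lower numbers for an effect already at smaller amounts. Compound 1 `Cn1cc(C(=O)O)c2ccc(N3CCC4(C=C(c5c(-c6c(Cl)cccc6Cl)noc5C5CC5)C4)CC3)cc21` gives 45 nM, compound 3 `O=C(O)c1cc(F)c2nc(N3CCC(CCc4c(-c5c(Cl)cccc5Cl)noc4C4CC4)CC3)sc2c1` gives 21.4 nM, and compound 2 `O=C(O)c1ccc2cc(N3CCC4(C=C(c5c(-c6c(Cl)cc(F)cc6Cl)noc5C5CC5)C4)CC3)ccc2n1` gives 522 nM, the highest of the three numbers, with its steps to both others beyond the scatter. Compound 4 `O=C(O)c1ccc2cc(N3CCC4(C=C(c5c(-c6c(Cl)cncc6Cl)noc5C5CC5)C4)CC3)ccc2n1` differs from compound 2 by 3,5-dichloropyridin-4-yl in place of 2,6-dichloro-4-fluorophenyl on an aromatic carbon. No step between two measured compounds bears on this change, so the size of the shift in this assay cannot be read from the numbers shown. Compound 4 is expected to stay near compound 2, with at most a modest move toward a higher number. The step is estimated as a 1.4-fold higher number from compound 2 to compound 4 (0.16 log units; within the scatter). Compound 4 is therefore estimated at 750 nM, within a range from 250 nM to 2500 nM.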

Compound 4, half-maximal effective concentration: 206 nM
Compound 4: the middle estimate sits 3.6-fold (0.56 log units) above what was measured, and the stated range ends above it.
By their numbers in this assay, from the lowest: compound 3; then compound 1; then compound 4; then compound 2.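

In this assay, the group on the aromatic carbon of the five-membered ring can move the read-out: 3,5-dichloropyridin-4-yl in place of 2,6-dichloro-4-fluorophenyl gives a 2.5-fold lower number from compound 2 to compound 4 (0.40 log units; beyond the scatter), a modest step beyond the scatter. It is the first step shown at this place, and it shows that a ring with a hetero atom can stand there without a move toward a higher number. Nothing measured here explains the step. As far as these compounds go, whether the ring nitrogen or the missing fluorine carries it stays open, and a plain 2,6-dichlorophenyl on this same core would separate the two. From the compounds shown here alone, how a nitrile or a methoxy group in place of that fluorine would read also remains open.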